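Amide variation on the shared core

A few compounds are considered here, and "the series" means these few. Any claim that something is new, unique, unknown or untested is made for them only; others in the source may bear on it.

Three amides of the shared core have been measured in a functional assay on HepG2 cells (Homo sapiens) for antiproliferative activity, read by MTT assay, with a stated time of 48 h; a higher number here means that more compound is needed for the effect, a lower number that less compound is needed. Compound 1 `Cc1ccccc1C(=O)Nc1nnc(-c2ccc3c(c2)OCCO3)s1` returns only the limit > 100 ug/mL, not a number. Compound 2 `Nc1ccc(C(=O)Nc2nnc(-c3ccc4c(c3)OCCO4)s2)cc1` likewise returns only the limit > 100 ug/mL. Going by the values given here, compound 3 `O=C(Nc1nnc(-c2ccc3c(c2)OCCO3)s1)c1ccc(Cl)nc1` gives 15.4 ug/mL, the only number in the set. The step from compound 1 to compound 3 is an at least 6.4-fold lower number from compound 1 to compound 3 (0.81 log units; beyond the scatter), and the step from compound 2 to compound 3 is an at least 6.4-fold lower number from compound 2 to compound 3 (0.81 log units; beyond the scatter), both beyond the scatter.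

Compound 4 `O=C(/C=C/c1ccccc1)Nc1nnc(-c2ccc3c(c2)OCCO3)s1` is still to be measured in this assay. Relative to compound 3 it carries 2-phenylethenyl in place of 6-chloropyridin-3-yl on a carbonyl carbon. Among the compounds with values here, no measured step removes the 6-chloropyridin-3-yl group and none introduces a 2-phenylethenyl group, so the measured steps bear on this change only indirectly: they show that the group on the carbonyl carbon can move the read-out by at least a modest amount, with two of three values sitting at the limit of > 100 ug/mL in this assay, at which 2 of the 3 values shown sit. The step from compound 3 to compound 4 is expected to be a 2.3-fold higher number from compound 3 to compound 4 (0.36 log units; beyond the scatter), towards a higher number, with a real chance that only a limit is reported. Compound 4 is estimated at 35 ug/mL, between 10 ug/mL and 120 ug/mL.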

Compound 4, half-maximal effective concentration: 10.3 ug/mL
The estimate for compound 4 lay 3.4-fold (0.53 log units) above the measured number; the measured number falls inside the stated range.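

In this assay, the 2-phenylethenyl group on the carbonyl carbon shows that a readable value at this position does not depend on the 6-chloropyridin-3-yl group: the exchange is a 1.5-fold lower number from compound 3 to compound 4 (0.17 log units; within the scatter), so the two groups cannot be told apart in this assay. The contrast with the other two amides also holds for a second, structurally different group, with an at least 9.7-fold lower number from compound 2 to compound 4 (0.98 log units; beyond the scatter) and an at least 9.7-fold lower number from compound 1 to compound 4 (0.98 log units; beyond the scatter). Compound 1 and compound 2 each return only a limit, not a number, so both of these steps give minimum sizes and their true sizes stay unknown: the limit of > 100 ug/mL in this assay, at which 2 of the 4 values shown sit.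

As far as these compounds go, it remains open whether the double bond of the 2-phenylethenyl group is needed, a question that a saturated 2-phenylethyl chain or a plain phenyl group on the carbonyl carbon would address. The role of the chlorine in the 6-chloropyridin-3-yl group is also unresolved, and an unsubstituted pyridin-3-yl group would test it directly.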